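The compounds below may be only part of what the source reports. "The series", "measured", "known", "first", "only" and "open" are said of these compounds alone.

Compound 1 `COc1ccc(/C=C(/SCc2ccc(Cl)cc2)C(=O)c2ccc(Br)cc2)cc1` is measured in a functional assay on DU-145 cells (Homo sapiens) for inhibition, read by trypan blue exclusion, with a stated time of 96 h (on this read-out higher numbers stand for weaker inhibition of growth and lower numbers for stronger inhibition of growth), where compound 1 gives 10000 nM. Its closest neighbour among the measured compounds is compound 2 `COc1ccc(/C=C(/SCc2ccc(Cl)cc2)C(=O)c2ccc(Cl)cc2)cc1`, which in this assay gives 10000 nM. The two differ only by a chloro in place of a bromo on an aromatic carbon, and that step, no change at the digits printed from compound 1 to compound 2 (within the scatter), stays within the scatter of repeated measurements, so compound 1 stands level with compound 2 on the numbers at hand.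

Compound 3 `COc1ccc(/C=C(/SCc2ccc(Cl)cc2)C(=O)c2ccc(Br)cc2)cc1O` has not yet been measured. It differs from compound 1 by hydroxy in place of hydrogen on an aromatic carbon

For the measured compounds named here, no measured step touches this kind of change: the only step available swaps one halogen for another on a different ring, and it moved nothing beyond the scatter. There is therefore no measured basis for expecting a shift in either direction, and the expectation for compound 3 is a step of no change at the digits printed from compound 1 to compound 3 (within the scatter) in this assay. On that basis compound 3 is estimated to give 10000 nM in this assay, with a likely range from 5000 nM to 20000 nM.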

Compound 3, concentration for 50% growth inhibition: 1000 nM
The estimate for compound 3 lay 10-fold (1.00 log units) above the measured number; measured number outside the range, below it.
By their numbers in this assay, from the lowest: compound 3; then compounds 1 and 2 (each within the scatter of the next).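

In this assay, the ring carrying the methoxy group proves responsive to a small change: going from 4-methoxyphenyl to 3-hydroxy-4-methoxyphenyl, with the hydroxy ortho to a methoxy group, gives a 10-fold lower number from compound 1 to compound 3 (1.00 log units; beyond the scatter) and so stronger inhibition of growth. The earlier pair changed only a halogen on a different ring and gave no change at the digits printed from compound 1 to compound 2 (within the scatter), so it offered no sign that any part of the shared core could move this read-out. Nothing available explains why this single added hydroxy has such an effect.

Going by these compounds, it remains open whether the change depends on the hydroxy itself, or whether an amine, a fluoro group or a second methoxy group at the same place would give a similar result, and whether a hydroxy would act in the same way without the neighbouring methoxy group. Compound 3 alone carries the hydroxy, so it is also unknown whether the same step would appear on the chloro-bearing compound 2 or with a carboxylic acid in place of the hydroxy.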